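The source may report more compounds than this note shows. Statements on the series, on what has been measured and on what is new or still open speak of the compounds shown alone.

Compound 2 `C[C@@H]1CC(=O)C=C2CC[C@](O)(C(C)(O)CO)C[C@]21C` and compound 1 `C[C@@H]1CC(=O)C=C2CC[C@@H]([C@@]3(C)CO3)C[C@]21C` share one core. In a functional assay on HL-60 cells (Homo sapiens) for antiproliferative activity, read by MTT assay (a lower number here means a stronger inhibitor, a higher number a weaker inhibitor), compound 2 gives 25.8 ug/mL, and compound 1 gives 27.6 ug/mL; these two values lie within the scatter of each other, so neither stands apart. Compound 3 `C[C@@H]1CC(=O)C=C2CC[C@@H](C(C)(O)CO)C[C@]21C` differs from compound 2 in one place: hydrogen in place of hydroxy on a saturated ring carbon. Within the data shown here, no step between measured compounds shows what this change does, so the step expected from a 1.0-fold higher number from compound 2 to compound 3 (0.00 log units; within the scatter) is none beyond the scatter. Compound 3 is therefore estimated at 26 ug/mL, with a range from 10 ug/mL to 65 ug/mL.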

Compound 3, concentration for 50% inhibition: 284 ug/mL
For compound 3 the middle estimate is 11-fold (1.04 log units) below the measured one, outside the stated range (above it).
By their numbers in this assay, from the lowest: compounds 2 and 1 (each within the scatter of the next); then compound 3.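

In this assay, hydrogen in place of hydroxy on this saturated ring carbon gives an 11-fold higher number from compound 2 to compound 3 (1.04 log units; beyond the scatter) as a large step, so the group at this carbon can matter a great deal. Compound 1 also has hydrogen on that carbon, yet 1-hydroxy-1-(hydroxymethyl)ethyl in place of 2-methyloxiran-2-yl gives a 10-fold higher number from compound 1 to compound 3 (1.01 log units; beyond the scatter) as a step just as large, so the effect of losing the hydroxy depends on the neighbouring group named in each compound. No data here explain either step. Going by these compounds, whether an amine, a fluorine or a methoxy on that ring carbon would act like the hydroxy remains open.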